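The source may hold more compounds than are shown below. What is called first, only, known or untested is meant among the compounds shown, and "the series" means these compounds.

Three amides sharing one core have been tested in a functional assay on MCF7 cells (Homo sapiens) for antiproliferative activity, read by MTT assay, with a stated time of 72 h; on this read-out higher numbers stand for weaker inhibition and lower numbers for stronger inhibition. Compound 1 `O=C(Nc1ccc(Cl)c(-c2nnc3c(Cl)cccn23)c1)c1ccccn1` gives 96400 nM and compound 3 `O=C(Nc1ccc(Cl)c(-c2nnc3c(Cl)cccn23)c1)c1ccc(C(F)(F)F)cc1F` gives 62800 nM. Compound 2 `Cc1nc(C(=O)Nc2ccc(Cl)c(-c3nnc4c(Cl)cccn34)c2)cs1` reaches only a limit of the assay, > 100000 nM. The step of an at least 1.0-fold higher number from compound 1 to compound 2 (0.01 log units; that floor lies within the scatter) is thus only a floor, and compound 2 stands at the limit of > 100000 nM in this assay, at which 1 of the 3 values shown sits, rather than at a number. Compound 4 `O=C(Nc1ccc(Cl)c(-c2nnc3c(Cl)cccn23)c1)c1cccc(Cl)c1` differs from compound 2 by 3-chlorophenyl in place of 2-methyl-1,3-thiazol-4-yl on a carbonyl carbon. For the measured compounds named here, the single step that bears on exchanging the ring on the carbonyl carbon, from compound 1 to compound 2, is bounded by that limit, so no shift beyond the scatter is expected in this assay. Compound 4 is therefore estimated at 100000 nM, between 40000 nM and 250000 nM. The step of a number no higher from compound 2 to compound 4 (the limit leaves the size open) that this estimate means is expected to stay within the scatter.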

Compound 4, half-maximal inhibitory concentration: 71900 nM
Compound 4: middle estimate off by 1.4-fold (0.14 log units), on the high side; measured number inside the range.
By their numbers in this assay, from the lowest: compounds 3, 4 and 1 (each within the scatter of the next). At a limit, above all of these: compound 2.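

In this assay the change to 3-chlorophenyl gives an at least 1.3-fold lower number from compound 2 to compound 4 (0.14 log units; that floor lies within the scatter), and the same group set against pyridin-2-yl gives a 1.3-fold lower number from compound 1 to compound 4 (0.13 log units; within the scatter). Going by these compounds, on this carbonyl carbon, then, a six-membered aromatic ring of carbon only with a chlorine does not move the number beyond the scatter from pyridin-2-yl, while the true size of the step from 2-methyl-1,3-thiazol-4-yl stays open. Compound 2 still stands at a limit and not at a number: the limit of > 100000 nM in this assay, at which 1 of the 4 values shown sits.

The compounds shown leave open whether any group at this place can shift the number beyond the scatter. An amine, a carboxylic acid or a longer chain on the carbonyl carbon could answer that.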